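Changing the Group on the Ring Nitrogen: Compound 3

A few compounds are considered here, and "the series" means these few. Any claim that something is new, unique, unknown or untested is made for them only; others in the source may bear on it.

In a functional assay on PC-12 cells (Rattus norvegicus) for cytotoxicity, read by MTT assay, with stated times of 2 h and 24 h, tested at 5 uM (on this read-out lower numbers stand for a weaker effect and higher numbers for a stronger effect at the one concentration tested), the measured compounds read:
compound 1 `CC(C)(C)c1ccc(-n2nc(-c3ccc(C(F)(F)F)cc3O)nc2-c2ccccc2O)cc1`: 77.8%
compound 2 `Oc1cc(C(F)(F)F)ccc1-c1nc(-c2ccccc2O)n(-c2ccccc2C(F)(F)F)n1`: 80%

Compound 1 has the lower of these two numbers, yet the step of a number 2.2 percentage points higher from compound 1 to compound 2 (within the scatter) lies within the scatter, so the two cannot be told apart. Compound 3 `COc1ccccc1-n1nc(-c2ccc(C(F)(F)F)cc2O)nc1-c1ccccc1O` differs from compound 1 in one place: 2-methoxyphenyl in place of 4-(tert-butyl)phenyl on an aromatic nitrogen. For the measured compounds named here, the only comparable step, a number 2.2 percentage points higher from compound 1 to compound 2 (within the scatter), also replaced the 4-(tert-butyl)phenyl on that aromatic nitrogen and moved nothing beyond the scatter, so no step beyond the scatter is expected here either, a number 0.2 percentage points higher from compound 1 to compound 3 (within the scatter). Compound 3 is therefore estimated at 78%, with a range from 66% to 90%.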

Compound 3, a percentage reported as activity, at one concentration (the size of the read-out at that concentration, not a potency): 85.6%
Compound 3: middle estimate off by 7.6 percentage points, on the low side, within the range that was stated.
By their numbers in this assay, from the lowest: compounds 1, 2 and 3 (each within the scatter of the next).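

With 2-methoxyphenyl on the aromatic nitrogen, this assay shows a number 7.8 percentage points higher from compound 1 to compound 3 (within the scatter) and a number 5.6 percentage points higher from compound 2 to compound 3 (within the scatter) so an entering group that holds an oxygen and a hydrogen-bond acceptor is not told apart from either earlier group. At this position, 4-(tert-butyl)phenyl, 2-(trifluoromethyl)phenyl and 2-methoxyphenyl therefore give readings within the scatter of one another. No measurement here accounts for this result. Still open, on these data alone, is whether a group without an aromatic ring, such as a short alkyl chain, or a phenyl carrying an amine or a carboxylic acid, would read differently on this nitrogen.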